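Alkyl chains on the indole nitrogen of a fused quinone

The compounds below may be only part of what the source reports. "The series", "measured", "known", "first", "only" and "open" are said of these compounds alone.

Measured compounds, with their numbers in a functional assay on A-375 cells (Homo sapiens) for cytotoxicity, read by MTT assay, with a stated time of 72 h; a lower number here means a stronger inhibitor, a higher number a weaker inhibitor:
- compound 1, `CN1CCN(CCCCCCn2c3c(c4ccccc42)C(=O)c2c[n+]([O-])c4ccccc4c2C3=O)CC1`, gives 630 nM
- compound 2, `CN1CCN(CCCCCn2c3c(c4ccccc42)C(=O)c2c[n+]([O-])c4ccccc4c2C3=O)CC1`, gives 1710 nM
- compound 3, `O=C1c2c[n+]([O-])c3ccccc3c2C(=O)c2[nH]c3ccccc3c21`, gives 660 nM

Compound 3 carries a bare hydrogen on the aromatic nitrogen and stands second highest of the three numbers in this assay; its number sits within the scatter of compound 1 and differs from compound 2 by a 2.6-fold lower number from compound 2 to compound 3 (0.41 log units; beyond the scatter). The step of a 2.7-fold higher number from compound 1 to compound 2 (0.43 log units; beyond the scatter) shows that shortening the chain by one carbon, with the same 4-methylpiperazin-1-yl end group, cost a modest amount.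

Compound 4, `O=C1c2c[n+]([O-])c3ccccc3c2C(=O)c2c1c1ccccc1n2CCCCN1CCCCC1`, differs from compound 3 by 4-(piperidin-1-yl)butyl in place of hydrogen on an aromatic nitrogen. The step that bears most on this change is a 2.6-fold lower number from compound 2 to compound 3 (0.41 log units; beyond the scatter), which shows that removing a five-carbon chain with a basic ring from the aromatic nitrogen lowered the number modestly; the new chain is shorter and ends in a different saturated ring, so that step gives only a loose guide, and the step of a 2.7-fold higher number from compound 1 to compound 2 (0.43 log units; beyond the scatter) shows that chain length matters at this position. On this basis compound 4 is expected to lie somewhat above compound 3 in this assay, with the estimated step of a 1.5-fold higher number from compound 3 to compound 4 (0.18 log units; within the scatter), and its estimated value is 1000 nM within a range of 350 nM to 3000 nM.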

Compound 4, half-maximal inhibitory concentration: 190 nM
Compound 4: middle estimate off by 5.3-fold (0.72 log units), on the high side, and the stated range ends above it.
By their numbers in this assay, from the lowest: compound 4; then compounds 1 and 3 (each within the scatter of the next); then compound 2.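

In this assay, within the data shown here, placing 4-(piperidin-1-yl)butyl on the aromatic nitrogen gives a 3.5-fold lower number from compound 3 to compound 4 (0.54 log units; beyond the scatter), so a chain here can go with a lower number than the bare hydrogen, something the earlier compounds did not show: compound 1 lies within the scatter of compound 3, and compound 2 lies above it. The piperidin-1-yl compound also stands apart from both 4-methylpiperazin-1-yl compounds, with a 9.0-fold lower number from compound 2 to compound 4 (0.95 log units; beyond the scatter) and a 3.3-fold lower number from compound 1 to compound 4 (0.52 log units; beyond the scatter), which gives compound 4 the lowest number of the set, although chain length and end group change together in these two steps and their shares cannot be separated. No measurement offered here accounts for the change.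

The compounds shown leave open how 4-methylpiperazin-1-yl would read on a butyl chain and how piperidin-1-yl would read on a pentyl or hexyl chain, the pairs that would separate the two changes. They also leave open whether a morpholine ring, a dimethylamino end or a longer chain at this position would follow compound 4 or the 4-methylpiperazin-1-yl compounds.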